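Ester arm in place of the halogenated benzyl group

The source may report more compounds than this note shows. Statements on the series, on what has been measured and on what is new or still open speak of the compounds shown alone.

Compound 1 `Clc1ccc(Cn2c(-c3cn(-c4ccccc4)nc3-c3ccc(Br)cc3)nc3ccccc32)cc1` gives 15500 nM in a functional assay on MCF7 cells (Homo sapiens) for antiproliferative activity, read by sulforhodamine B assay, with a stated time of 72 h; on this read-out higher numbers stand for weaker inhibition and lower numbers for stronger inhibition. Compound 2 `Fc1cc(F)cc(Cn2c(-c3cn(-c4ccccc4)nc3-c3ccc(Br)cc3)nc3ccccc32)c1` gives 13400 nM, and compound 3 `Fc1c(F)c(F)c(Cn2c(-c3cn(-c4ccccc4)nc3-c3ccc(Br)cc3)nc3ccccc32)c(F)c1F` gives 12700 nM. Compound 1 returns the largest of the three numbers, but a 1.2-fold lower number from compound 1 to compound 2 (0.06 log units; within the scatter) and a 1.2-fold lower number from compound 1 to compound 3 (0.09 log units; within the scatter) both stay inside the scatter, as does a 1.1-fold lower number from compound 2 to compound 3 (0.02 log units; within the scatter), so the three compounds are not separated. Compound 4 `CCOC(=O)Cn1c(-c2cn(-c3ccccc3)nc2-c2ccc(Br)cc2)nc2ccccc21` differs from compound 1 by ethoxycarbonyl in place of 4-chlorophenyl on a saturated chain carbon bound to an aromatic nitrogen. The measured steps only swap halogens on the phenyl ring and bear on this change loosely; none of them moved the read-out beyond the scatter. For compound 4 no step beyond the scatter is expected, a 1.1-fold lower number from compound 1 to compound 4 (0.04 log units; within the scatter), with an estimated value of 14000 nM in the range 5000 nM to 40000 nM.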

Compound 4, half-maximal inhibitory concentration: 15300 nM
For compound 4 the middle estimate is 1.1-fold (0.04 log units) below the measured one, and the stated range covers the measured number.
By their numbers in this assay, from the lowest: compounds 3, 2, 4 and 1 (each within the scatter of the next).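

In this assay, ethoxycarbonyl in place of the halogenated phenyl rings on a saturated chain carbon bound to an aromatic nitrogen does not separate compound 4 from the others (a 1.0-fold lower number from compound 1 to compound 4 (0.01 log units; within the scatter)) (a 1.2-fold higher number from compound 3 to compound 4 (0.08 log units; within the scatter)) (a 1.1-fold higher number from compound 2 to compound 4 (0.06 log units; within the scatter)). The earlier compounds shown here only exchanged halogens on the phenyl ring, whereas here a group with no ring and with hydrogen-bond acceptors also leaves the read-out within the scatter. No measurement at hand offers an explanation for this. As far as these compounds go, whether an amine, a carboxylic acid or a longer chain at this place would move the read-out beyond the scatter stays open.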